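A few compounds are considered here, and "the series" means these few. Any claim that something is new, unique, unknown or untested is made for them only; others in the source may bear on it.

Compound 1 `CCCn1ccc2cc(/C(C)=C/C(=O)Nc3ccccc3OCCCC(=O)O)ccc21` gives 190 nM in an assay on Prostate gland for inhibition of steroid 5-alpha-reductase (Rattus norvegicus) (on this read-out lower numbers stand for stronger inhibition and higher numbers for weaker inhibition), the highest of the two numbers recorded. Compound 2 `C/C(=C\C(=O)Nc1ccccc1OCCCC(=O)O)c1ccc2c(ccn2Cc2ccccc2C)c1`, which differs from it only at the saturated chain carbon bound to the aromatic nitrogen, gives 69 nM, a step of a 2.8-fold lower number from compound 1 to compound 2 (0.44 log units; beyond the scatter). Compound 3 `C/C(=C\C(=O)Nc1ccccc1OCCCC(=O)O)c1ccc2c(ccn2Cc2ccc(C)cc2)c1` carries 4-methylphenyl in place of ethyl on a saturated chain carbon bound to an aromatic nitrogen. Within the data shown here, the one step that bears on this change, the one from compound 1 to compound 2, was modest but beyond the scatter, so a step of like size and direction is expected, estimated as a 2.2-fold lower number from compound 1 to compound 3 (0.35 log units; beyond the scatter). Compound 3 is therefore expected to give about 85 nM, within a range of 35 nM to 210 nM.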

Compound 3, half-maximal inhibitory concentration: 88 nM
Compound 3: the middle estimate sits 1.0-fold (0.02 log units) below what was measured; measured number inside the range.
By their numbers in this assay, from the lowest: compounds 2 and 3 (each within the scatter of the next); then compound 1.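

In this assay the change from propyl to 4-methylbenzyl also lowers the number, with a 2.2-fold lower number from compound 1 to compound 3 (0.33 log units; beyond the scatter), so the drop seen with compound 2 is not tied to the 2-methylphenyl group alone. Exchanging 2-methylphenyl for 4-methylphenyl gives a 1.3-fold higher number from compound 2 to compound 3 (0.11 log units; within the scatter), so the two groups are not told apart at this position. No evidence is available that accounts for these results. The compounds shown leave open whether the methyl group matters at all, which a plain benzyl group would show, and how a ring carrying an amine or a carboxylic acid would compare.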